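Swapping the Amino Group on the Benzamide Ring of Compound 3

The source may report more compounds than this note shows. Statements on the series, on what has been measured and on what is new or still open speak of the compounds shown alone.

Measured compounds:
compound 1, `CN(C)CCCN(Cc1ccccc1)c1ccc(C(=O)N2CCc3ccc(OS(N)(=O)=O)cc3C2)cc1`, gives 61.6% in an assay on HEK293 cells for inhibition of Steryl-sulfatase (Homo sapiens), tested at 1 uM; a lower number here means a weaker effect, a higher number a stronger effect of the compound at the concentration tested
compound 2, `NS(=O)(=O)Oc1ccc2c(c1)CN(C(=O)c1cccc(N3CCC(N4CCCCC4)CC3)c1)CC2`, gives 8% in this assay
compound 3, `CC(C)CCN(CCC(C)C)c1cccc(C(=O)N2CCc3ccc(OS(N)(=O)=O)cc3C2)c1`, gives 75.9% in this assay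

Compound 3 stands highest of the three numbers; compound 1 comes nearest, below it by a gap beyond the scatter, and compound 2 lies far below, also beyond the scatter. Compound 4, `CCN(Cc1ccncc1)c1cccc(C(=O)N2CCc3ccc(OS(N)(=O)=O)cc3C2)c1`, has not been measured yet. It differs from compound 3 in one place: ethyl((pyridin-4-yl)methyl)amino in place of diisopentylamino on an aromatic carbon. Within the data shown here, no measured pair of compounds shows this exchange, so there is no direct guide to its effect. A moderate fall in inhibition is expected, as a number 30.9 percentage points lower from compound 3 to compound 4 (beyond the scatter). Compound 4 is accordingly estimated at 45%, with a likely range from 15% to 75%.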

Compound 4, a percentage reported as inhibition, at one concentration (the size of the read-out at that concentration, not a potency): 52.8%
Beside the measured number, compound 4's estimate is 7.8 percentage points below it; the measured number falls inside the stated range.
By their numbers in this assay, from the lowest: compound 2; then compounds 4 and 1 (each within the scatter of the next); then compound 3.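

Among these compounds, the step gives a number 23.1 percentage points lower from compound 3 to compound 4 (beyond the scatter) in this assay as ethyl((pyridin-4-yl)methyl)amino replaces diisopentylamino, the first direct reading of a change on this aromatic carbon. Inhibition falls but is not lost, so an amino group carrying a six-membered aromatic ring with a ring nitrogen is tolerated here, as well as one with two open chains. Nothing available explains the fall.

The compounds shown do not separate the ethyl part of the new group from its pyridine part. A diethylamino group on this aromatic carbon would help to tell them apart.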